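This account rests on a few compounds, and the source may have more. Where it says the series, first, only, none or still open, it means among the compounds named here.

Measured so far:
compound 1 `C[n+]1ccn(COCC[Si](C)(C)C)c1/C=N/O` — -0.34
compound 2 `C[n+]1ccn(CCC#N)c1/C=N/O` — -3.3
compound 3 `C[n+]1ccn(CCOCCCl)c1/C=N/O` — -2.32

In a physicochemical assay for lipophilicity (on this read-out lower numbers stand for lower lipophilicity and higher numbers for higher lipophilicity), compound 3 stands second highest of the three; compound 2 sits nearest, and compound 1 sits furthest, with the higher number. The step of a number 0.98 log units higher from compound 2 to compound 3 (beyond the scatter) is the only one measured at this part of the molecule. Compound 4 `C[n+]1ccn(COCCCBr)c1/C=N/O` carries the change (3-bromopropoxy in place of (2-chloroethoxy)methyl on a saturated chain carbon bound to an aromatic nitrogen). Within the data shown here, that swap keeps the chain at the same count of heavy atoms and the same single acceptor, exchanging chlorine for bromine; no measured step covers it directly, so the step from compound 2 to compound 3 is only a rough guide. A small rise in this assay is therefore expected, a number 0.42 log units higher from compound 3 to compound 4 (beyond the scatter). For compound 4 the estimate is -1.9, ranging from -2.5 to -1.3.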

Compound 4, distribution coefficient: -1.76
Compound 4: middle estimate off by 0.14 log units, on the low side; the measured number falls inside the stated range.
By their numbers in this assay, from the lowest: compound 2; then compound 3; then compound 4; then compound 1.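

In this assay this position responds even when the count of heavy atoms stays the same: 3-bromopropoxy in place of (2-chloroethoxy)methyl gives a number 0.56 log units higher from compound 3 to compound 4 (beyond the scatter) and not a flat result. Compound 4 also sits between the two outer compounds, with a number 1.54 log units higher from compound 2 to compound 4 (beyond the scatter) and a number 1.42 log units lower from compound 1 to compound 4 (beyond the scatter) as its steps to them. No supporting evidence accounts for these shifts.

Chlorine and bromine change together with the arrangement of the chain, and the compounds shown do not separate the two. Going by these compounds, how a chain carrying an amine or a carboxylic acid would read also stays open.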